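The source may report more compounds than this note shows. Statements on the series, on what has been measured and on what is new or still open speak of the compounds shown alone.

Measured so far:
compound 1, `CNC(=O)c1cc(C(=O)N[C@H]2CC[C@H](O)CC2)n([C@@H](C)c2ccccc2)n1`: 0.9 mL/min
compound 2, `CNC(=O)c1cc(C(=O)N[C@H]2[C@@H]3COC[C@@H]32)c([C@@H](C)c2ccccc2)o1`: a limit only

In an ADME assay on cells (Hepatocyte, Rattus norvegicus, strain Wistar han) for metabolic stability, read by LC-MS, with a stated time of 60 min (a lower number here means slower removal, a higher number faster removal of the compound), compound 1 gives 0.9 mL/min. For compound 2 the assay returns a limit rather than a number, < 0.8 mL/min. Compound 2 thus sits at the limit of < 0.8 mL/min in this assay, at which 1 of the 2 values shown sits.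

Compound 3, `CNC(=O)c1cc(C(=O)N[C@H]2[C@@H]3C[C@@H](O)C[C@@H]32)c([C@@H](C)c2ccccc2)o1`, has not been measured. It differs from compound 2 by a group of 7 heavy atoms (6 carbon, 1 oxygen; one three-membered non-aromatic ring of carbon only, one five-membered non-aromatic ring of carbon only) in place of a group of 6 heavy atoms (5 carbon, 1 oxygen; one three-membered non-aromatic ring of carbon only, one five-membered non-aromatic ring with 1 hetero atom), on an amide-type nitrogen. The two known values both lie at the slow end of this assay, so for compound 3 no change beyond the usual scatter is expected, and the estimated step is an at least 1.2-fold higher number from compound 2 to compound 3 (0.09 log units; that floor lies within the scatter). Compound 3 is expected to give about 1 mL/min, most likely between 0.5 mL/min and 2 mL/min.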

Compound 3, intrinsic clearance in a liver preparation (reported as CLH), per the amount of preparation that the assay uses in the Hepatocyte assay: < 0.8 mL/min
Compound 3: no number, only a limit; the forecaster's own chance of this, stated with the estimate: 40%; at least 1.2-fold (0.09 log units) between middle value and limit.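

Going by these compounds alone, in the Hepatocyte assay compound 2 and compound 3 both return only a limit, so no step between them can be read. In a physicochemical assay for lipophilicity (on this read-out lower numbers stand for lower lipophilicity and higher numbers for higher lipophilicity), compound 2 gives a distribution coefficient (4.1) and compound 3 a lower one (2.8). Going by these compounds, whether this gap goes with any real difference in the Hepatocyte assay stays open.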